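A few compounds are considered here, and "the series" means these few. Any claim that something is new, unique, unknown or untested is made for them only; others in the source may bear on it.

Measured so far:
- compound 1, `Cn1ncc(Cl)c1-c1cc(C(=O)N[C@@H]2CN[C@H](CCNS(C)(=O)=O)C[C@H]2c2ccc(F)c(F)c2)oc1Cl`: 50 nM
- compound 2, `Cn1ncc(Cl)c1-c1cc(C(=O)N[C@@H]2CN[C@H](CC(O)CO)C[C@H]2c2ccc(Cl)c(Cl)c2)oc1Cl`: 70 nM
- compound 3, `Cn1ncc(Cl)c1-c1cc(C(=O)N[C@@H]2CN[C@H](CC(=O)O)C[C@H]2c2ccc(Cl)c(Cl)c2)oc1Cl`: 640 nM

In a functional assay on LNCaP cells (Homo sapiens) for antiproliferative activity (a higher number here means a weaker inhibitor, a lower number a stronger inhibitor), compound 2 gives 70 nM, the second highest of the three numbers. Its nearest neighbour is compound 1, whose 50 nM lies within the scatter of that of compound 2, so the two cannot be ordered. Its furthest is compound 3, reached by a 9.1-fold higher number from compound 2 to compound 3 (0.96 log units; beyond the scatter).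

The new compound 4, `Cn1ncc(Cl)c1-c1cc(C(=O)N[C@@H]2CN[C@H](CCN3CCCC3)C[C@H]2c2ccc(Cl)c(Cl)c2)oc1Cl`, has not yet been measured in this assay. It is made from compound 2 by the change ((pyrrolidin-1-yl)methyl in place of 1,2-dihydroxyethyl on a saturated chain carbon bound to a saturated ring carbon).

Among the measured compounds shown here, only one measured step touches the same position: a 9.1-fold higher number from compound 2 to compound 3 (0.96 log units; beyond the scatter). It shows that exchanging the 1,2-dihydroxyethyl for a carboxy costs potency. For the measured compounds named here, no measured pair shows a (pyrrolidin-1-yl)methyl, a chain nitrogen within a ring, or any group lacking hydrogen-bond donors at this place. Compound 1 carries a different chain and a different aryl group, so its number only shows that another side chain here can sit near that of compound 2.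

With such thin support, compound 4 is expected to stay close to compound 2, with a step of about a 1.6-fold lower number from compound 2 to compound 4 (0.19 log units; within the scatter), and its estimated value in this assay is 45 nM, ranging from 15 nM to 150 nM.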

Compound 4, half-maximal inhibitory concentration: 1920 nM
Compound 4: the middle estimate sits 43-fold (1.63 log units) below what was measured, and the stated range ends below it.
By their numbers in this assay, from the lowest: compounds 1 and 2 (each within the scatter of the next); then compound 3; then compound 4.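

In this assay, among the compounds shown here, the place on a saturated chain carbon bound to a saturated ring carbon proves less forgiving than the earlier compounds could show: putting (pyrrolidin-1-yl)methyl in place of 1,2-dihydroxyethyl gives a 27-fold higher number from compound 2 to compound 4 (1.44 log units; beyond the scatter), a larger loss than the only earlier step here, a 9.1-fold higher number from compound 2 to compound 3 (0.96 log units; beyond the scatter). The new group also falls short of the carboxy, with a 3.0-fold higher number from compound 3 to compound 4 (0.48 log units; beyond the scatter), so both replacements of the 1,2-dihydroxyethyl shown at this place lose potency, and they do so to different degrees. Nothing measured on these compounds accounts for the size of this loss.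

The compounds shown leave open whether the loss follows the pyrrolidine ring, the chain nitrogen or the departure of the two hydroxyl groups, a question that a primary amine, a dimethylamine or a single hydroxyl on the same chain would help to separate. They also leave open whether a morpholine ring or a longer chain ending in pyrrolidine would fare any better in this assay.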